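Naphthalene to chlorophenyl at the chain terminus: melanocortin antagonism

The compounds below may be only part of what the source reports. "The series", "measured", "known", "first", "only" and "open" are said of these compounds alone.

Compound 1 `CCN(CC)CCCC(C)/N=C(/N)NC(=O)c1cccc(F)c1CCc1ccc2ccccc2c1` is one of three acylguanidines with the same fluorinated core and a two-carbon chain carrying an aromatic group. In a functional assay for antagonist activity at Melanocortin receptor 4 (Homo sapiens), read by cAMP accumulation (on this read-out lower numbers stand for stronger inhibition and higher numbers for weaker inhibition), compound 1 gives 1800 nM, the highest of the two numbers that exist for the series. The nearest measured entry is compound 3 `COc1ccc(Br)cc1CCc1c(F)cccc1C(=O)/N=C(\N)NCCCCN(C)Cc1ccccc1`, which in this assay gives 180 nM, a lower number beyond the scatter; compound 3 differs from compound 1 in the aromatic group, the chain and the amine, so no single change can be read from that pair. Compound 2 `CCN(CC)CCCC(C)/N=C(\NC(=O)c1cccc(F)c1CCc1cc(Br)ccc1OC)Nc1ccccc1` has no usable number in this assay: in this assay compound 2 gives "not determined" (no result reported).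

Compound 4 `CCN(CC)CCCC(C)/N=C(/N)NC(=O)c1cccc(F)c1CCc1ccccc1Cl` is compound 1 with one change: 2-chlorophenyl in place of naphthalen-2-yl on a saturated chain carbon, two bonds along the chain from an aromatic carbon. For the measured compounds named here, no measured pair shows this change on its own. Going by the values given here, the only guidance is that compound 1 sits at the weak end of the two known numbers and that a smaller aromatic group enters. On this basis compound 4 is expected to be weaker than compound 1 by a modest margin, possibly no further than the scatter; the expected step is a 1.7-fold higher number from compound 1 to compound 4 (0.22 log units; within the scatter). For compound 4 the estimated value in this assay is 3000 nM, with a range from 1000 nM to 9000 nM.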

Compound 4, half-maximal inhibitory concentration: > 33000 nM
Compound 4 ended at the assay's limit; the forecaster's own chance of this, stated with the estimate: 15%; middle value at least 11-fold (1.04 log units) from the limit.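

For the compounds shown here, this is the first comparison in which a single place changes, and it shows that the aromatic group on the two-carbon chain has a large bearing on antagonism: with the shared core and the amine chain held constant, 2-chlorophenyl in place of naphthalen-2-yl gives an at least 18-fold higher number from compound 1 to compound 4 (1.26 log units; beyond the scatter) in this assay. Compound 4 gives > 33000 nM, which is a limit of the assay and not a number. The step therefore fixes only a minimum size, and its full size cannot be read: the limit of > 33000 nM in this assay, at which 1 of the 4 values shown sits.

The two groups differ both in the second aromatic ring and in the chlorine, so the compounds shown leave open which of these carries the step; a plain phenyl group at this place would separate the two. On these data alone, whether a substituted phenyl group can serve here also stays open: compound 3 carries one on the same two-carbon chain and gives 180 nM, but it differs from compound 1 in the amine chain as well, so no step can be read from that pair.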